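Branched acyl exchange on the shared core: compound 1 to 3

The source may hold more compounds than are shown below. What is called first, only, known or untested is meant among the compounds shown, and "the series" means these compounds.

Compound 1 `CC(C)CC(=O)O[C@@H]1OC=C(CO[C@@H]2O[C@H](CO)[C@@H](O)[C@H](O)[C@H]2OC(=O)/C=C/c2ccc(O)cc2)[C@H]2CC[C@](O)(CO)[C@@H]12` sits at the top of the measurable range of a functional assay on A549 cells (Homo sapiens) for cytotoxicity, read by sulforhodamine B assay, with a stated time of 48 h; a lower number here means a stronger inhibitor, a higher number a weaker inhibitor. In this assay compound 1 gives only a limit, > 10000 nM. Compound 2 `CC(C)CC(=O)O[C@@H]1OC=C(CO[C@@H]2O[C@H](CO)[C@@H](O)[C@H](O)[C@H]2OC(=O)/C=C\c2ccc(O)cc2)[C@H]2CC[C@](O)(CO)[C@@H]12` also gives only a limit in this assay, > 10000 nM. The step that the two limits leave unreadable from compound 1 to compound 2 cannot be sized, because of the limit of > 10000 nM in this assay, at which 2 of the 2 values shown sit; the pair is distinguished solely by the fact that compounds 1 and 2 differ only in the configuration as drawn. Compound 3 `CCC(C)C(=O)O[C@@H]1OC=C(CO[C@@H]2O[C@H](CO)[C@@H](O)[C@H](O)[C@H]2OC(=O)/C=C/c2ccc(O)cc2)[C@H]2CC[C@](O)(CO)[C@@H]12` carries sec-butyl in place of isobutyl on a carbonyl carbon. Within the data shown here, no measured step touches this position; the one step in hand, a step that the two limits leave unreadable from compound 1 to compound 2, lies elsewhere in the molecule and is itself unreadable, so the expectation rests on the two limits alone. Compound 3 is expected to remain at the limit in this assay, with the step that the limit leaves unreadable from compound 1 to compound 3 expected to stay within the scatter. The estimate for compound 3 is 15000 nM, with a range from 7000 nM to 40000 nM.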

Compound 3, half-maximal inhibitory concentration: 3800 nM
Estimate against measurement, compound 3: 3.9-fold (0.60 log units) above, and the stated range ends above it.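

In this assay, among these compounds, the acyl position gives the first readable step: an at least 2.6-fold lower number from compound 1 to compound 3 (0.42 log units; beyond the scatter). Compound 3 and compound 1 have the same atoms, joined differently, so moving from isobutyl to sec-butyl on the carbonyl carbon is enough to bring compound 3 to a measurable 3800 nM. Compound 1 gives > 10000 nM, which is a limit, so the step fixes only a minimum size.

With only isobutyl and sec-butyl shown at this position, it remains open how a longer chain, such as n-hexyl, or an acyl group carrying an amine would read. Also open is whether the drawn configuration of the double bond matters on the sec-butyl compound, since the step from compound 1 to compound 2 cannot be read, due to: the limit of > 10000 nM in this assay, at which 2 of the 3 values shown sit.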